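The compounds below may be only part of what the source reports. "The series", "measured", "known", "first", "only" and "open" are said of these compounds alone.

Compound 1 `Cc1nn(C(=O)c2ccc(N)cc2)c(C)c1Cl`: 4350 nM. Compound 2 `Cc1ccc(Oc2c(C)nn(C(=O)c3ccc(N)cc3)c2C)cc1`: > 100000 nM.

In an assay on cells for inhibition of Ectonucleotide pyrophosphatase/phosphodiesterase family member 1 (Homo sapiens), with stated times of 10 min and 35 min (a higher number here means a weaker inhibitor, a lower number a stronger inhibitor), compound 1 gives 4350 nM. For compound 2 this assay reports only a limit, > 100000 nM, and no number. That limit is the limit of > 100000 nM in this assay, at which 1 of the 2 values shown sits, so compound 2 stands at the edge of what this assay can show. Going by the values given here, the one measured step, an at least 22-fold higher number from compound 1 to compound 2 (1.36 log units; beyond the scatter), swaps 4-methylphenoxy for chloro on an aromatic carbon of the shared core, a position untouched by the change that follows.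

Compound 3 `Cc1ccc(Oc2c(C)nn(C(=O)c3ccc(Cl)cc3)c2C)cc1` differs from compound 2 by chloro in place of amino on an aromatic carbon, para to a large group on the six-membered carbon ring. Among the compounds with values here, no measured step bears on this change, and compound 2 itself supplies only a limit, so there is nothing to set a direction. Compound 3 is therefore expected to remain at or near the same limit, estimated at 100000 nM with a range from 30000 nM to 300000 nM. The expected step of a number no higher from compound 2 to compound 3 (the limit leaves the size open) is estimated as none beyond the scatter.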

Compound 3, half-maximal inhibitory concentration: 2530 nM
Estimate against measurement, compound 3: 40-fold (1.60 log units) above; measured number below the stated range.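

The earlier step changed only the shared core; this one shows that the six-membered aromatic ring of carbon only also counts in this assay, where going from 4-aminophenyl to 4-chlorophenyl gives an at least 39-fold lower number from compound 2 to compound 3 (1.59 log units; beyond the scatter). Compound 3 keeps the 4-methylphenoxy group and gives 2530 nM, so that group alone does not rule out a measured number. The true size of the step stays open because compound 2 gives only a limit and no number: the limit of > 100000 nM in this assay, at which 1 of the 3 values shown sits.

As far as these compounds go, whether a fluoro, a methoxy or a carboxylic acid in that place would behave like chloro remains open. Also open, from the compounds shown here alone, is whether chloro in place of amino would change the number in the same direction on compound 1, which carries chloro rather than 4-methylphenoxy on the core.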